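The source may hold more compounds than are shown below. What is called first, only, known or untested is meant among the compounds shown, and "the series" means these compounds.

Compound 2 `COc1cc(/C=N/NC(=O)c2ccncc2)cc(O)c1O` gives 8% in a physicochemical assay on cells (Homo sapiens), with a stated time of 18 h, tested at 10 uM; on this read-out higher numbers stand for a weaker effect at the one concentration tested and lower numbers for a stronger effect. Within the data shown here, of the three numbers so far it stands second highest, nearest to compound 1 `COc1cc(/C=N/NC(=O)c2ccncc2)cc(OC)c1O`, which gives 7%, and furthest from compound 3 `COc1cc(/C=N/NC(=O)OCc2ccccc2)ccc1O`, which gives 36%; that last gap lies beyond the scatter, the first within it. Among the measured compounds shown here, the one measured step, a number 1 percentage points higher from compound 1 to compound 2 (within the scatter), is within the scatter. Compound 4 `O=C(N/N=C/c1ccc(O)c(O)c1)c1ccncc1` is the next member: hydrogen in place of methoxy on an aromatic carbon. The group that leaves sits ortho to a hydroxy group and meta to a hydroxy group. For the measured compounds named here, only the step from compound 1 to compound 2 bears on this change; it altered the same oxygen on the aromatic ring, turning methoxy into hydroxy, and left this assay unmoved beyond the scatter. Going by the values given here, no measured pair removes the whole methoxy group. On that basis no step beyond the scatter is expected in this assay, and the estimated change is a number 2 percentage points higher from compound 2 to compound 4 (within the scatter). Compound 4 is expected to give 10%, within a range from 2% to 25%.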

Compound 4, a percentage reported as activity, at one concentration (the size of the read-out at that concentration, not a potency): 4%
Estimate against measurement, compound 4: 6 percentage points above; measured number inside the range.
By their numbers in this assay, from the lowest: compounds 4, 1 and 2 (each within the scatter of the next); then compound 3.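

Hydrogen in place of methoxy on this aromatic carbon, ortho to a hydroxy group and meta to a hydroxy group, gives in this assay a number 4 percentage points lower from compound 2 to compound 4 (within the scatter). The whole methoxy group can therefore go from this position with no step beyond the scatter, which extends the earlier finding on the same ring, a number 1 percentage points higher from compound 1 to compound 2 (within the scatter), where only the methyl on the oxygen was replaced. No measured data bear on why the read-out holds across this change.

Still open, from the compounds shown here alone, is whether an amine, a carboxylic acid or a longer alkoxy chain on this carbon would move the read-out beyond the scatter. Compound 3 differs from compound 4 in more than one place, so its steps to the other compounds cannot be read and do not show which part of the structure carries its higher number.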